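Anilide variation on a nitrobenzoxadiazole glutathione transferase probe

The compounds below may be only part of what the source reports. "The series", "measured", "known", "first", "only" and "open" are said of these compounds alone.

Measured so far:
Compound 1, `O=C(CCC(=O)OCCCCCCSc1ccc([N+](=O)[O-])c2nonc12)Nc1ccccc1`: 700 nM
Compound 2, `O=C(CCC(=O)OCCCCCCSc1ccc([N+](=O)[O-])c2nonc12)Nc1ccc(C(F)(F)F)cc1`: 90 nM

In an assay on isolated protein for inhibition of glutathione S-transferase Mu 2 (Homo sapiens), with a stated time of 10 min (on this read-out lower numbers stand for stronger inhibition and higher numbers for weaker inhibition), compound 1 gives 700 nM. Compound 2 carries a trifluoromethyl on the anilide ring and in this assay gives 90 nM. Among the compounds with values here, the only measured step is a 7.8-fold lower number from compound 1 to compound 2 (0.89 log units; beyond the scatter). Compound 2 thus has the lowest number of the two, and its nearest neighbour is compound 1.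

Compound 3, `COc1ccc(NC(=O)CCC(=O)OCCCCCCSc2ccc([N+](=O)[O-])c3nonc23)cc1OC`, has not yet been measured. It differs from compound 2 by 3,4-dimethoxyphenyl in place of 4-(trifluoromethyl)phenyl on an amide-type nitrogen. Within the data shown here, no measured step shows what a dimethoxy pattern on this ring does; the one step available, a 7.8-fold lower number from compound 1 to compound 2 (0.89 log units; beyond the scatter), only shows that placing a trifluoromethyl on the anilide ring moved the number well beyond the scatter. Compound 3 lacks that group and instead carries two methoxy groups, so the number is expected to move back toward that of compound 1, though possibly not all the way. For compound 3 the expected step is a 3.9-fold higher number from compound 2 to compound 3 (0.59 log units; beyond the scatter), an increase beyond the scatter. Compound 3 is therefore estimated at 350 nM, with a range from 100 nM to 1500 nM.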

Compound 3, half-maximal inhibitory concentration: 360 nM
For compound 3 the middle estimate is 1.0-fold (0.01 log units) below the measured one, and the stated range covers the measured number.
By their numbers in this assay, from the lowest: compound 2; then compounds 3 and 1 (each within the scatter of the next).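

In this assay, 3,4-dimethoxyphenyl in place of 4-(trifluoromethyl)phenyl on the amide-type nitrogen gives (a 4.0-fold higher number from compound 2 to compound 3 (0.60 log units; beyond the scatter)), so the low number of compound 2 does not extend to every substituted anilide. The comparison with the unsubstituted anilide (a 1.9-fold lower number from compound 1 to compound 3 (0.29 log units; within the scatter)) stays within the scatter, which means that adding the two methoxy groups to the phenyl leaves compound 3 and compound 1 unresolved in this assay, and among these three compounds only compound 2 stands apart from the other two. Nothing measured here bears on the reason for this difference.

The two methoxy groups enter together, so the compounds shown cannot tell what either one contributes alone, nor whether a single methoxy would behave like the pair. They also leave open whether a nitrile, a chlorine, an amine or a carboxylic acid on the anilide ring would give a number near that of compound 2 or near those of compound 3 and compound 1, and whether a longer chain on the sulfur would alter these steps.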